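Amino to Phenyl on the Carbonyl-Bearing Ring of Compound 2

The source may report more compounds than this note shows. Statements on the series, on what has been measured and on what is new or still open speak of the compounds shown alone.

Three measured compounds share one core and differ only in the ring joined to the carbonyl carbon. In a functional assay on A549 cells (Homo sapiens) for antiproliferative activity, read by MTT assay, with a stated time of 48 h (on this read-out lower numbers stand for stronger inhibition and higher numbers for weaker inhibition), compound 1 `COc1ccc(/C=C/c2cc(OC)cc(OC)c2/C=C/C(=O)c2cccc(Br)c2)cc1` gives 8.1 ug/mL. Compound 2 `COc1ccc(/C=C/c2cc(OC)cc(OC)c2/C=C/C(=O)c2ccc(N)cc2)cc1` gives 3.8 ug/mL, the lowest of the three numbers, and compound 3 `CCCC(C)Oc1ccc(C(=O)/C=C/c2c(/C=C/c3ccc(OC)cc3)cc(OC)cc2OC)cc1` gives 9.4 ug/mL. The steps around compound 2 are a 2.1-fold lower number from compound 1 to compound 2 (0.33 log units; beyond the scatter) and a 2.5-fold higher number from compound 2 to compound 3 (0.39 log units; beyond the scatter), while the direct comparison a 1.2-fold higher number from compound 1 to compound 3 (0.06 log units; within the scatter) shows the 3-bromophenyl and 4-(1-methylbutoxy)phenyl rings giving numbers within the scatter of one another.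

Compound 4 `COc1ccc(/C=C/c2cc(OC)cc(OC)c2/C=C/C(=O)c2ccc(-c3ccccc3)cc2)cc1` differs from compound 2 by phenyl in place of amino on an aromatic carbon.

The step most relevant to this change is a 2.5-fold higher number from compound 2 to compound 3 (0.39 log units; beyond the scatter), in which the amino group left the same aromatic carbon and a larger group without donors or acceptors entered, and the number rose modestly. The step of a 1.2-fold higher number from compound 1 to compound 3 (0.06 log units; within the scatter) adds that a large group in place of a small one on that ring moved nothing beyond the scatter. Because a 2.5-fold higher number from compound 2 to compound 3 (0.39 log units; beyond the scatter) followed the loss of the amino group, a modest rise in the number is expected here too, estimated as a 2.2-fold higher number from compound 2 to compound 4 (0.35 log units; beyond the scatter). Compound 4 is therefore expected to give 8.5 ug/mL, with a likely range from 3.5 ug/mL to 20 ug/mL.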

Compound 4, half-maximal inhibitory concentration: 4.6 ug/mL
Beside the measured number, compound 4's estimate is 1.8-fold (0.27 log units) above it, within the range that was stated.
By their numbers in this assay, from the lowest: compounds 2, 4, 1 and 3 (each within the scatter of the next, the first and the last beyond it).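

In this assay, the step to phenyl is a 1.2-fold higher number from compound 2 to compound 4 (0.08 log units; within the scatter) and so stays within the scatter, which shows that among these compounds a number close to that of compound 2 does not depend on keeping the amino group, even though phenyl brings no hydrogen-bond donor or acceptor to this aromatic carbon. The earlier step from amino to 1-methylbutoxy could have suggested that losing the amino group alone raises the number, but the comparison between the two large groups, a 2.0-fold lower number from compound 3 to compound 4 (0.31 log units; beyond the scatter) and so beyond the scatter, shows that the group that enters also matters. The remaining step, a 1.8-fold lower number from compound 1 to compound 4 (0.25 log units; within the scatter) and also within the scatter, means that the 4-phenylphenyl and 3-bromophenyl rings cannot be told apart here, so compound 4 lies within the scatter of both compound 1 and compound 2, although those two lie beyond it from each other.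

Still open, on these data alone, is whether a hydroxyl group, a carboxylic acid or a cyclohexyl ring on the same aromatic carbon would give a number near that of compound 2 or nearer that of compound 3. Nothing shown here gives a measured reason for these differences.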